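Swapping the fluoropiperidine for cyclopentylamine in an oral series

The compounds below may be only part of what the source reports. "The series", "measured", "known", "first", "only" and "open" are said of these compounds alone.

Compound 1 `Cc1cn2c(-c3cn[nH]c3)cnc2c(Nc2cc(C(c3ccccn3)N3CCCCC3)ns2)n1` gives 99 ng.h/mL in an ADME assay on the whole organism for pharmacokinetics, with Rattus norvegicus as the target, with a stated time of 6 h, at a dose of 10 mg/kg by the oral route; on this read-out higher numbers stand for higher exposure at the dose given and lower numbers for lower exposure. Compound 2 `Cc1cn2c(-c3cn[nH]c3)cnc2c(Nc2cc(C(c3ccccn3)N3CCC(F)CC3)ns2)n1`, which carries fluoro in place of hydrogen on a saturated ring carbon, gives 220 ng.h/mL in this assay, a change of a 2.2-fold higher number from compound 1 to compound 2 (0.35 log units; beyond the scatter). Compound 2 thus stands highest of the two measured numbers, with compound 1 the nearer one below it. Compound 3 `Cc1cn2c(-c3cn[nH]c3)cnc2c(Nc2cc(C(NC3CCCC3)c3ccccn3)ns2)n1` differs from compound 2 by cyclopentylamino in place of 4-fluoropiperidin-1-yl on a saturated chain carbon bound to two aromatic carbons. Among the measured compounds shown here, only the single step from compound 1 to compound 2 bears on this change, and it was modest; the new change removes that fluoro and replaces the whole ring, which the measured step does not cover. Compound 3 is therefore expected to come out close to compound 2 or somewhat lower, a step of a 1.8-fold lower number from compound 2 to compound 3 (0.26 log units; within the scatter). The estimate for compound 3 is 120 ng.h/mL, within 40 ng.h/mL to 350 ng.h/mL.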

Compound 3, area under the concentration-time curve: 316 ng.h/mL
Beside the measured number, compound 3's estimate is 2.6-fold (0.42 log units) below it, and the stated range covers the measured number.
By their numbers in this assay, from the lowest: compound 1; then compounds 2 and 3 (each within the scatter of the next).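

In this assay, cyclopentylamino takes the place of 4-fluoropiperidin-1-yl on the saturated chain carbon bound to two aromatic carbons with a step that stays within the scatter, a 1.4-fold higher number from compound 2 to compound 3 (0.16 log units; within the scatter). Set against the unfluorinated ring, the same position shows a step beyond the scatter, a 3.2-fold higher number from compound 1 to compound 3 (0.50 log units; beyond the scatter), so neither a piperidine ring nor a fluoro group is required here for the exposure seen with compound 2. No available measurement accounts for either step.

From the compounds shown here alone, it remains open whether the hydrogen on the cyclopentylamino nitrogen matters, which a methyl(cyclopentyl)amino group would address. A fluorocyclopentylamino group would show whether the step seen on adding fluoro to the piperidine ring carries over to the cyclopentyl ring.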